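A few compounds are considered here, and "the series" means these few. Any claim that something is new, unique, unknown or untested is made for them only; others in the source may bear on it.

Compound 1 `Cc1cc(Nc2cc(-c3ccccc3)[nH]n2)n2nc(SCc3c(Cl)cccc3Cl)nc2n1` gives 5180 nM
Compound 2 `Cc1cc(Nc2cc(-c3ccccc3)[nH]n2)n2nc(SCc3cccc(Br)c3)nc2n1` gives 8900 nM
Compound 3 `Cc1cc(Nc2cc(-c3ccccc3)[nH]n2)n2nc(SCc3nc4ccccc4[nH]3)nc2n1` gives 4840 nM

In a functional assay on PC-9 cells (Homo sapiens) for inhibition, read by MTT assay, with a stated time of 72 h (a lower number here means a stronger inhibitor, a higher number a weaker inhibitor), compound 3 gives 4840 nM and stands within the scatter of the other two compounds (a 1.1-fold lower number from compound 1 to compound 3 (0.03 log units; within the scatter); a 1.8-fold lower number from compound 2 to compound 3 (0.26 log units; within the scatter)). Compound 4 `COc1ccc(CSc2nc3nc(C)cc(Nc4cc(-c5ccccc5)[nH]n4)n3n2)cc1` keeps the shared core and differs from compound 3 by one exchange (4-methoxyphenyl in place of 1H-benzimidazol-2-yl on a saturated chain carbon bound to a sulfur): 4-methoxyphenyl in place of 1H-benzimidazol-2-yl on a saturated chain carbon bound to a sulfur. Among the compounds with values here, the third measured step at this place (a 1.7-fold higher number from compound 1 to compound 2 (0.24 log units; within the scatter)) also stayed within the scatter, though no measured compound carries 4-methoxyphenyl. So in this assay no step beyond the scatter is expected. The estimated step is small (a 1.2-fold higher number from compound 3 to compound 4 (0.09 log units; within the scatter)). Compound 4 is expected near 6000 nM with an estimated range from 3000 nM to 12000 nM for the measurement.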

Compound 4, half-maximal inhibitory concentration: 8110 nM
For compound 4 the middle estimate is 1.4-fold (0.13 log units) below the measured one, within the range that was stated.
By their numbers in this assay, from the lowest: compounds 3, 1, 4 and 2 (each within the scatter of the next).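

With 4-methoxyphenyl on a saturated chain carbon bound to a sulfur, every step in this assay to an earlier compound still stays within the scatter (a 1.7-fold higher number from compound 3 to compound 4 (0.22 log units; within the scatter)) (a 1.1-fold lower number from compound 2 to compound 4 (0.04 log units; within the scatter)) (a 1.6-fold higher number from compound 1 to compound 4 (0.19 log units; within the scatter)). An oxygen-bearing phenyl group thus joins the halogen-bearing phenyl groups and 1H-benzimidazol-2-yl at this place, and no exchange among the four shows a step beyond the scatter. No supporting evidence bears on this result.

The compounds shown leave open whether an amine, a carboxylic acid or a longer chain at this place would give a step beyond the scatter.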